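The source may hold more compounds than are shown below. What is called first, only, known or untested is meant among the compounds shown, and "the series" means these compounds.

Measured so far:

compound 1, `C[C@@H](NC1CCN(CCCc2c[nH]c3ccc(-n4cnnc4)cc23)CC1)c1ccccc1`: in an assay on CHO cells for displacement of a labelled ligand from 5-hydroxytryptamine receptor 1D (Homo sapiens) (on this read-out lower numbers stand for stronger inhibition and higher numbers for weaker inhibition), compound 1 gives 0.4 nM
compound 2, `CN(Cc1ccccc1)CC1CCN(CCCc2c[nH]c3ccc(-n4cnnc4)cc23)CC1`: compound 2 gives 0.9 nM
compound 3, `c1ccc2c(c1)CCC2NCC1CCN(CCCc2c[nH]c3ccc(-n4cnnc4)cc23)CC1`: compound 3 gives 1.1 nM

The three compounds share one core and differ only in the group carried on a saturated ring carbon of the six-membered non-aromatic ring with one nitrogen. Compound 3 has the highest of the three numbers; its gap to compound 2 is within the scatter, whereas the step of a 2.8-fold higher number from compound 1 to compound 3 (0.44 log units; beyond the scatter) lies beyond it, so compound 3 is the weaker of that pair but not clearly separated from compound 2.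

Compound 4, `c1cc(CNC2CCN(CCCc3c[nH]c4ccc(-n5cnnc5)cc34)CC2)co1`, varies the same position once more: ((furan-3-yl)methyl)amino in place of ((2,3-dihydro-1H-inden-1-yl)amino)methyl on a saturated ring carbon. Going by the values given here, the steps seen at this position so far bear on it. One is a 2.3-fold higher number from compound 1 to compound 2 (0.35 log units; beyond the scatter). Another is a 1.2-fold higher number from compound 2 to compound 3 (0.09 log units; within the scatter). The third is the step from compound 1 to compound 3 named above. All three are modest. Swapping one group for another here has so far moved the number only a little, so a modest shift is expected for compound 4 as well, most likely toward a somewhat higher number.

Compound 4 is therefore expected to give about 2 nM in this assay, plausibly between 0.7 nM and 6 nM. That estimate corresponds to a 1.8-fold higher number from compound 3 to compound 4 (0.26 log units; within the scatter), an expected step no larger than those already seen at this position.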

Compound 4, half-maximal inhibitory concentration: 4.5 nM
Estimate against measurement, compound 4: 2.3-fold (0.35 log units) below; low and high end bracket the measured number.
By their numbers in this assay, from the lowest: compound 1; then compounds 2 and 3 (each within the scatter of the next); then compound 4.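

In this assay, going by these compounds alone, the largest step at this position so far comes from a change on the amine nitrogen alone, with (furan-3-yl)methyl in place of 1-phenylethyl giving an 11-fold higher number from compound 1 to compound 4 (1.05 log units; beyond the scatter) and moving this read-out further than any earlier exchange. Compound 4 also separates from the other two compounds, with a 4.1-fold higher number from compound 3 to compound 4 (0.61 log units; beyond the scatter) and a 5.0-fold higher number from compound 2 to compound 4 (0.70 log units; beyond the scatter) showing that this position does not accept every exchange as quietly as the first steps suggested. Nothing available here explains why the number rises.

Compound 1 and compound 4 differ both in the aromatic ring and in the methyl on the carbon bound to the amine nitrogen, and the data do not separate these two changes. A plain benzyl group or a (thiophen-3-yl)methyl group on that nitrogen would help to tell them apart.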